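The source may report more compounds than this note shows. Statements on the series, on what has been measured and on what is new or still open speak of the compounds shown alone.

Of the compounds shown here, three built on one shared core have been measured in an assay on HEK293 cells for displacement of a labelled ligand from NPC1-like intracellular cholesterol transporter 1 (Homo sapiens); a lower number here means a stronger inhibitor, a higher number a weaker inhibitor. Compound 1 `CC(C)(C)OC(=O)NC1CCCN(C(=O)CN2CN(c3ccccc3)C3(CCN(C(=O)c4ccc(C5CCCCC5)cc4)CC3)C2=O)C1` gives 4400 nM there, and compound 3 `CS(=O)(=O)NCCCNC(=O)CN1CN(c2ccccc2)C2(CCN(C(=O)c3ccc(C4CCCCC4)cc3)CC2)C1=O` gives 3800 nM. Compound 2 `CC(C)(C)c1ccc(C(=O)N2CCC3(CC2)C(=O)N(CC(=O)N2CCNCC2)CN3c2ccccc2)cc1` gives 22000 nM in this assay, the highest of the three numbers, and its distance from both compound 1 and compound 3 lies beyond the usual scatter, so compound 2 is the weakest inhibitor among the three.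

Compound 4 `CC(C)(C)c1ccc(C(=O)N2CCC3(CC2)C(=O)N(CC(=O)NCN)CN3c2ccccc2)cc1` is the next compound to be measured. It differs from compound 2 in a single place: (aminomethyl)amino in place of piperazin-1-yl on a carbonyl carbon

For the measured compounds named here, no pair of measured compounds isolates this change, so there is no measured step to lean on. Compound 1 and compound 3 carry open-chain groups on the corresponding carbonyl and sit lower than compound 2, but each of them also differs from compound 2 in the group on the outer benzoyl ring, so their numbers cannot be read as the effect of this one change. The expectation for compound 4 is therefore a modest step toward a lower number, small enough that it may stay within the scatter, a 1.5-fold lower number from compound 2 to compound 4 (0.17 log units; within the scatter). Compound 4 is estimated to give 15000 nM in this assay, in a range from 5000 nM to 45000 nM.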

Compound 4, half-maximal inhibitory concentration: 26500 nM
Compound 4: the middle estimate sits 1.8-fold (0.25 log units) below what was measured; measured number inside the range.
By their numbers in this assay, from the lowest: compounds 3 and 1 (each within the scatter of the next); then compounds 2 and 4 (each within the scatter of the next).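

In this assay, placing (aminomethyl)amino instead of piperazin-1-yl on the carbonyl carbon gives a 1.2-fold higher number from compound 2 to compound 4 (0.08 log units; within the scatter), so this pair cannot be told apart. The exchange removes one six-membered non-aromatic ring, replaces 6 heavy atoms with 3 and raises the hydrogen-bond donor count from 1 to 2, yet the measured inhibition stays within the usual scatter, which shows that, for this pair, keeping the ring closed is not needed to hold the number at this level. Nothing available explains why such different groups give matching values, so this result stands as an observation without a cause.

Two groups at one position cannot show how far this tolerance extends, and a carboxylic acid, a morpholine ring or a longer chain ending in an amine could give a quite different number on the same carbonyl carbon. As far as these compounds go, it also remains open whether exchanging piperazin-1-yl for (aminomethyl)amino would give a similarly small step if the group on the outer benzoyl ring were different.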